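A few compounds are considered here, and "the series" means these few. Any claim that something is new, unique, unknown or untested is made for them only; others in the source may bear on it.

Compound 3 `COc1cc(OC)c2c(=O)cc(-c3ccc(Br)cc3)oc2c1` stands lowest of the three numbers in a functional assay (Homo sapiens) for antiproliferative activity, read by resazurin assay, with a stated time of 48 h, tested at 20 uM (on this read-out lower numbers stand for a weaker effect and higher numbers for a stronger effect at the one concentration tested), giving 22%. For comparison, compound 1 `COc1cc(OC)c2c(=O)cc(-c3ccc(OCCCN(C)C)cc3)oc2c1` gives 86% and compound 2 `COc1cc(OC)c2c(=O)cc(-c3ccc(OCC(O)CN(C)C)cc3)oc2c1` gives 71% in this assay. Compound 4 `COc1cc(OC)c2c(=O)cc(-c3ccc(NCCN(C)C)cc3)oc2c1` has not yet been measured; it differs from compound 3 in one place: (2-(dimethylamino)ethyl)amino in place of bromo on an aromatic carbon. Going by the values given here, two measured steps bear on this change, each running the opposite way: a number 64 percentage points lower from compound 1 to compound 3 (beyond the scatter) and a number 49 percentage points lower from compound 2 to compound 3 (beyond the scatter). In both, bromo took the place of a 3-(dimethylamino)propoxy or a 3-(dimethylamino)-2-hydroxypropoxy group and the effect fell sharply. Reversing that kind of change, with (2-(dimethylamino)ethyl)amino entering, is therefore expected to give a large upward step, a number 53 percentage points higher from compound 3 to compound 4 (beyond the scatter). Compound 4 is accordingly estimated at 75%, expected to lie between 50% and 92%.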

Compound 4, a percentage reported as inhibition, at one concentration (the size of the read-out at that concentration, not a potency): 84%
Beside the measured number, compound 4's estimate is 9 percentage points below it, and the stated range covers the measured number.
By their numbers in this assay, from the lowest: compound 3; then compound 2; then compounds 4 and 1 (each within the scatter of the next).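

In this assay the step of a number 62 percentage points higher from compound 3 to compound 4 (beyond the scatter) shows that the effect at this aromatic carbon does not depend on an oxygen link, since (2-(dimethylamino)ethyl)amino also carries it. The steps of a number 2 percentage points lower from compound 1 to compound 4 (within the scatter) and of a number 13 percentage points higher from compound 2 to compound 4 (beyond the scatter) leave it indistinguishable from the 3-(dimethylamino)propoxy chain and ahead of the 3-(dimethylamino)-2-hydroxypropoxy chain. Nothing measured here explains these steps. On these data alone, it remains open whether a morpholine or piperidine in place of the dimethylamino end would keep this effect. As far as these compounds go, a longer chain on the same nitrogen link also remains untested in these compounds.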